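Chromone oxime ethers: fluoro to methoxy on the aryl

The source may hold more compounds than are shown below. What is called first, only, known or untested is meant among the compounds shown, and "the series" means these compounds.

Measured so far:
Compound 1 `C/C(COc1ccc2c(=O)cc(-c3ccccc3)oc2c1)=N\O`: 2800000 nM
Compound 2 `O=c1cc(-c2ccccc2)oc2cc(OC/C(=N/O)c3ccc(F)cc3)ccc12`: 2300000 nM

Both numbers come from a functional assay on SK-HEP1 cells (Homo sapiens) for antiproliferative activity; on this read-out higher numbers stand for weaker inhibition of growth and lower numbers for stronger inhibition of growth. Among the compounds with values here, the only measured step is a 1.2-fold lower number from compound 1 to compound 2 (0.09 log units; within the scatter), so compound 2 sits at the lower end of the two numbers but cannot be separated from compound 1, its single neighbour.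

Compound 3 `COc1ccc(/C(COc2ccc3c(=O)cc(-c4ccccc4)oc3c2)=N\O)cc1` is not yet measured. It differs from compound 2 by methoxy in place of fluoro on an aromatic carbon. Within the data shown here, no measured step touches the substituent on that aromatic ring; the one measured step, a 1.2-fold lower number from compound 1 to compound 2 (0.09 log units; within the scatter), exchanged the whole group on the oxime carbon and stayed within the scatter. There is thus no basis for expecting a shift in either direction in this assay, and the step of no change at the digits printed from compound 2 to compound 3 (within the scatter) is expected to lie within the scatter. Compound 3 is therefore estimated at 2300000 nM, with a range of 1000000 nM to 5500000 nM.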

Compound 3, concentration for 50% growth inhibition: 5600000 nM
For compound 3 the middle estimate is 2.4-fold (0.39 log units) below the measured one; the measured number lies above the stated range.
By their numbers in this assay, from the lowest: compounds 2, 1 and 3 (each within the scatter of the next, the first and the last beyond it).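

In this assay, within the data shown here, methoxy in place of fluoro on the aromatic carbon para to a large group gives a 2.4-fold higher number from compound 2 to compound 3 (0.39 log units; beyond the scatter), the first step beyond the scatter, so the substituent at this position can shift the number, if only modestly. Set against the methyl group of compound 1, the 4-methoxyphenyl group gives a 2.0-fold higher number from compound 1 to compound 3 (0.30 log units; within the scatter), which stays within the scatter, so neither aryl group separates from methyl and the only separation lies between the two aryl groups themselves. Nothing available bears on the reason for the fluoro to methoxy step.

Going by these compounds, with one pair at this position, it remains open whether the shift tracks the arrival of methoxy or the loss of fluoro. Plain hydrogen, chloro, an amine or a carboxylic acid at the same place would show whether any group here moves the number lower than compound 2 does.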